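The compounds below may be only part of what the source reports. "The series", "measured", "known", "first", "only" and "open" are said of these compounds alone.

Compound 1 `Nc1nc2c(c(-c3ccccc3)cn2[C@@H]2O[C@H](CO)[C@@H](O)[C@H]2O)c(=O)[nH]1` carries a phenyl group on its shared core. In a functional assay on HL-60 cells (Homo sapiens) for antiproliferative activity, read by XTT assay, with a stated time of 72 h (a higher number here means a weaker inhibitor, a lower number a stronger inhibitor), compound 1 yields no number but only a limit, > 20000 nM. That limit is where one of the three measured values sits (the limit of > 20000 nM in this assay, at which 1 of the 3 values shown sits). Two further compounds rest on different cores. Compound 2 `COc1ncnc2c1c(-c1ccsc1)cn2[C@@H]1O[C@H](CO)[C@@H](O)[C@H]1O` gives 130 nM in this assay. Compound 3 `C#Cc1cn([C@@H]2O[C@H](CO)[C@@H](O)[C@H]2O)c2ncnc(NC)c12` gives 9060 nM in this assay. Among the measured compounds shown here, neither shares the core of compound 1, so no single-point step connects them to it.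

Compound 4 `Nc1nc2c(c(-c3cc4ccccc4o3)cn2[C@@H]2O[C@H](CO)[C@@H](O)[C@H]2O)c(=O)[nH]1` differs from compound 1 in one place: 1-benzofuran-2-yl in place of phenyl on an aromatic carbon. For the measured compounds named here, no measured step of this kind is available, and the starting point itself is only a limit, so any forecast rests on thin ground. Compound 4 is expected to stay a weak inhibitor in this assay, with an estimated value of 15000 nM, plausibly between 3000 nM and 40000 nM. The step that this estimate implies, an at least 1.3-fold lower number from compound 1 to compound 4 (0.12 log units; that floor lies within the scatter), is expected to be at most modest, and a second limit would not surprise.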

Compound 4, half-maximal inhibitory concentration: > 20000 nM
Compound 4 gave a limit, no number; the forecaster's own chance of this, stated with the estimate: 50%; middle value at least 1.3-fold (0.12 log units) away from the limit.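

Among the compounds shown here, compound 4 gives only a limit in this assay, as compound 1 does, so no step between these two compounds can be read: the limit of > 20000 nM in this assay, at which 2 of the 4 values shown sit. The compounds shown leave open whether 1-benzofuran-2-yl in place of phenyl changes the activity on the shared core at all.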